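The source may hold more compounds than are shown below. What is called first, only, known or untested is meant among the compounds shown, and "the series" means these compounds.

In a functional assay on 786-0 cells (Homo sapiens) for inhibition (on this read-out higher numbers stand for weaker inhibition of growth and lower numbers for stronger inhibition of growth), compound 1 (`COc1ccc(-n2cnnc2-c2cc(OC)c(OC)c(OC)c2)cc1`) gives 2510 nM, compound 2 (`COc1cc(-c2nncn2-c2ccc(N(C)C)cc2)cc(OC)c1OC`) gives 398 nM and compound 3 (`COc1ccc(-n2cnnc2-c2cc(OC)c(OC)c(OC)c2)cc1O`) gives 501 nM. Compound 3 thus lies within the scatter of compound 2 and well under compound 1. Compound 4 (`COc1ccc(-n2cnnc2-c2cc(OC)c(OC)c(OC)c2)cc1F`) carries fluoro in place of hydroxy on an aromatic carbon, ortho to a methoxy group and meta to a large group: fluoro in place of hydroxy on an aromatic carbon. The step bearing most directly on this is a 5.0-fold lower number from compound 1 to compound 3 (0.70 log units; beyond the scatter), with hydroxy in place of hydrogen. The step of a 6.3-fold lower number from compound 1 to compound 2 (0.80 log units; beyond the scatter), with dimethylamino in place of methoxy, is a different change. Among the compounds with values here, no fluoro compound has been measured. Compound 4 has no hydroxy, so a modest move back towards compound 1 is expected, though probably not all the way. The expected change in this assay is a 2.4-fold higher number from compound 3 to compound 4 (0.38 log units; beyond the scatter). Compound 4 is estimated at 1200 nM, within an expected range of 300 nM to 5000 nM.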

Compound 4, concentration for 50% growth inhibition: 3160 nM
The estimate for compound 4 lay 2.6-fold (0.42 log units) below the measured number; the measured number falls inside the stated range.
By their numbers in this assay, from the lowest: compounds 2 and 3 (each within the scatter of the next); then compounds 1 and 4 (each within the scatter of the next).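

In this assay fluoro in place of hydroxy gives a 6.3-fold higher number from compound 3 to compound 4 (0.80 log units; beyond the scatter) and fluoro in place of hydrogen gives a 1.3-fold higher number from compound 1 to compound 4 (0.10 log units; within the scatter) at this position, ortho to a methoxy group. The lower number seen with hydroxy is therefore not kept with fluoro, and here fluoro does not set itself apart from hydrogen. Nothing measured here accounts for this difference between hydroxy and fluoro. Going by these compounds, whether an amine or a carboxylic acid at this position would follow hydroxy or fluoro stays open.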